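The source may report more compounds than this note shows. Statements on the series, on what has been measured and on what is new or still open speak of the compounds shown alone.

Notes on the series. Compound 1 `O=C(Nc1nc(-c2cccc(C(F)(F)F)c2F)cs1)c1ccc(N2CCC(C(=O)O)CC2)nc1`, compound 2 `O=C(Nc1nc(-c2cccc(C(F)(F)F)c2F)cs1)c1cnc(N2CCC(C(=O)O)CC2)c(C(F)(F)F)c1` and compound 3 `Cc1cc(C(=O)Nc2nc(-c3cccc(C(F)(F)F)c3F)cs2)cnc1N1CCC(C(=O)O)CC1` share one core and differ only in a substituent on the six-membered aromatic ring with one nitrogen. In a physicochemical assay for solubility (a higher number here means a more soluble compound, a lower number a less soluble compound), compound 1 reports only an assay limit, < 10 ug/mL. In this assay compound 2 likewise reports only a limit, < 10 ug/mL. Compound 3 too stands at a limit, < 10 ug/mL. The steps a step that the two limits leave unreadable from compound 1 to compound 2, a step that the two limits leave unreadable from compound 1 to compound 3 and a step that the two limits leave unreadable from compound 2 to compound 3 therefore carry no readable size, as the limit of < 10 ug/mL in this assay, at which 3 of the 3 values shown sit, summarises. Compound 4 `O=C(Nc1nc(-c2cccc(C(F)(F)F)c2F)cs1)c1cnc(N2CCC(C(=O)O)CC2)c(F)c1` differs from compound 3 by fluoro in place of methyl on an aromatic carbon. Among the compounds with values here, none of the measured steps gives a direction to borrow, so no change beyond the scatter is expected. Compound 4 is expected to give 5 ug/mL, in the range 1 ug/mL to 15 ug/mL, most probably again as a limit. The expected step that the limit leaves unreadable from compound 3 to compound 4 is thus estimated to lie within the scatter.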

Compound 4, solubility: < 10 ug/mL
Compound 4: only a limit was reported (the forecaster's own chance of this, stated with the estimate: 75%); the middle value does not contradict the limit.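

In this assay compound 4 gives < 10 ug/mL, a limit of the assay. Within the data shown here, no step from compound 4 to compound 1, compound 2 or compound 3 can be read. The compounds shown leave open whether hydrogen, methyl, trifluoromethyl and fluoro differ at all in this read-out.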